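The source may hold more compounds than are shown below. What is called first, only, known or untested is meant among the compounds shown, and "the series" means these compounds.

Measured so far in a functional assay on HEK293 cells for agonist activity at Bombesin receptor subtype-3 (Homo sapiens), read by luminescence and calcium flux, with a stated time of 10 min; on this read-out higher numbers stand for an effect only at larger amounts of compound and lower numbers for an effect already at smaller amounts:
- compound 1 `CCC(C)(C)Cc1c[nH]c(CCc2ccc(-c3cccc(N)n3)cc2)n1` gives 97 nM
- compound 2 `CCC(C)(C)Cc1c[nH]c(CCc2ccc(-c3csnn3)cc2)n1` gives 104 nM
- compound 3 `CCC(C)(C)Cc1c[nH]c(CCc2ccc(-c3cnsc3)cc2)n1` gives 100 nM

Compound 3 sits second highest of the three numbers, yet the three lie so close that no order among them can be read: the step of a 1.0-fold higher number from compound 1 to compound 3 (0.01 log units; within the scatter) and the step of a 1.0-fold lower number from compound 2 to compound 3 (0.02 log units; within the scatter) are both within the scatter, as is a 1.1-fold higher number from compound 1 to compound 2 (0.03 log units; within the scatter). Three quite different aromatic groups at the same place on the shared core thus leave the result unchanged.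

Compound 4 `CCC(C)(C)Cc1c[nH]c(CCc2ccc(-c3cccnc3C(=O)O)cc2)n1` changes that place once more: 2-carboxypyridin-3-yl in place of 1,2-thiazol-4-yl on an aromatic carbon. Going by the values given here, the three measured steps are the only guide; each swapped one aromatic group for another at this spot and none moved the number beyond the scatter. Among the compounds with values here, the group that enters here, 2-carboxypyridin-3-yl, differs from all three earlier groups in carrying a carboxylic acid, a feature no measured compound has, so the guide is weaker than it looks and the range must be wider.

Compound 4 is therefore expected to show a step of a 1.6-fold higher number from compound 3 to compound 4 (0.20 log units; within the scatter), within the scatter in direction. Compound 4 is estimated at 160 nM, between 40 nM and 700 nM.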

Compound 4, half-maximal effective concentration: 95 nM
For compound 4 the middle estimate is 1.7-fold (0.23 log units) above the measured one; measured number inside the range.
By their numbers in this assay, from the lowest: compounds 4, 1, 3 and 2 (each within the scatter of the next).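

Placing 2-carboxypyridin-3-yl on this aromatic carbon brings in a carboxylic acid, which no earlier compound carried, yet in this assay the steps remain small: a 1.1-fold lower number from compound 3 to compound 4 (0.02 log units; within the scatter), a 1.1-fold lower number from compound 2 to compound 4 (0.04 log units; within the scatter) and a 1.0-fold lower number from compound 1 to compound 4 (0.01 log units; within the scatter). Going by these compounds alone, the position has therefore now taken a six-membered aromatic ring bearing a carboxylic acid, and a group with more heavy atoms than 1,2-thiazol-4-yl, with no step among the four compounds beyond the scatter. No available measurement bears on why the number holds steady.

On these data alone, all four groups here are aromatic rings, so it remains open whether a cyclohexyl ring or a single methyl group at this place would give a similar number. As far as these compounds go, it also remains open whether a methyl ester in place of the carboxylic acid would do so.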